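This account rests on a few compounds, and the source may have more. Where it says the series, first, only, none or still open, it means among the compounds named here.

Working notes on the series. For the measured compounds named here, in a functional assay on HCT-116 cells (Homo sapiens) for antiproliferative activity, read by MTT assay, with a stated time of 72 h (on this read-out higher numbers stand for weaker inhibition and lower numbers for stronger inhibition), compound 1 `CN(C(=O)c1ccc(F)cc1)c1ccc2[nH]c(-c3n[nH]c4ccccc34)cc2n1` gives 9270 nM, the lowest of the three numbers so far. Compound 2 `CN(C(=O)c1ccccc1)c1ccc2[nH]c(-c3n[nH]c4cc(Cl)ccc34)cc2n1` gives 13100 nM, a number within the scatter of compound 1. Compound 3 `CN(C(=O)c1ccccc1)c1ccc2[nH]c(-c3n[nH]c4cc(C#N)ccc34)cc2n1` gives 24000 nM, and its gap to compound 1 lies beyond the scatter. Going by the values given here, the only recorded step between neighbours differing in one place is a 1.8-fold higher number from compound 2 to compound 3 (0.26 log units; within the scatter); it concerns a substituent on the shared core and stays within the scatter.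

Compound 4 `CN(c1ccc2[nH]c(-c3n[nH]c4ccccc34)cc2n1)S(=O)(=O)c1ccccc1` is next for this assay. It differs from compound 1 by phenylsulfonyl in place of (4-fluorophenyl)carbonyl on a nitrogen on an aromatic ring. Among the compounds with values here, no measured step touches this nitrogen or exchanges a carbonyl for a sulfonyl, so the single recorded step gives no direction for the change. The (4-fluorophenyl)carbonyl of compound 1 against the benzoyl of compound 2 also allows no clean comparison, since those two compounds differ in two places. With nothing to lean on, the expectation in this assay is a step of no clear direction and no size beyond the scatter, with a wide range for the unknown: compound 4 is estimated at 12000 nM, between 4000 nM and 40000 nM, which means an expected step of a 1.3-fold higher number from compound 1 to compound 4 (0.11 log units; within the scatter).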

Compound 4, half-maximal inhibitory concentration: 6740 nM
Compound 4: middle estimate off by 1.8-fold (0.25 log units), on the high side; measured number inside the range.
By their numbers in this assay, from the lowest: compounds 4, 1, 2 and 3 (each within the scatter of the next, the first and the last beyond it).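

In this assay, for the compounds shown here, the first measured change at this nitrogen on an aromatic ring, phenylsulfonyl in place of (4-fluorophenyl)carbonyl, gives a 1.4-fold lower number from compound 1 to compound 4 (0.14 log units; within the scatter) and so shows that the position accepts a sulfonyl as well as a carbonyl with no step beyond the scatter. The two groups match in heavy-atom count and each carries one six-membered aromatic ring of carbon only, but the exchange swaps the carbonyl for a sulfonyl and removes the fluorine at once, so this single step cannot be divided between those two differences. No measurement on hand explains why the two numbers stay this close.

From the compounds shown here alone, whether this nitrogen holds its number with a group lacking the aromatic ring, such as methylsulfonyl or acetyl, remains open, as does the effect of an amine or a carboxylic acid carried on the phenyl ring of the phenylsulfonyl. Also open, going by these compounds, is whether the chloro and cyano substituents of compound 2 and compound 3 on the shared core would give the same numbers with phenylsulfonyl on this nitrogen.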